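Swapping an amide for an ester-bearing ring at the sulfur

This account rests on a few compounds, and the source may have more. Where it says the series, first, only, none or still open, it means among the compounds named here.

Compound 1 `N#Cc1c(N)nc(SCC(N)=O)c(C#N)c1-c1ccc(OCC2CC2)cc1` in an assay on CHO cells for displacement of a labelled ligand from adenosine receptor A3 (Homo sapiens), read by scintillation counting, with a stated time of 120 min, tested at 1 uM (on this read-out higher numbers stand for more inhibition at the one concentration tested (going by the name of the read-out) and lower numbers for less inhibition), gives 8%, the second highest of three numbers, though all three sit close together. Compound 2 `N#Cc1c(N)nc(SCc2ccn[nH]2)c(C#N)c1-c1ccc(OCC2CC2)cc1` gives 6% and compound 3 `N#Cc1c(N)nc2sc(C(N)=O)c(N)c2c1-c1ccc(OCC2CC2)cc1` gives 13%. Compound 4 `COC(=O)c1cccc(CSc2nc(N)c(C#N)c(-c3ccc(OCC4CC4)cc3)c2C#N)c1` differs from compound 1 in one place: 3-(methoxycarbonyl)phenyl in place of carbamoyl on a saturated chain carbon bound to a sulfur. Among the measured compounds shown here, the one measured step at this same position, a number 2 percentage points lower from compound 1 to compound 2 (within the scatter), lay within the scatter, so exchanging this group for another has not moved the number so far. Compound 4 carries a larger group here than either, and nothing measured points to a rise beyond the scatter. Compound 4 is therefore expected to stay close, with a step of a number 2 percentage points higher from compound 1 to compound 4 (within the scatter). The estimate for compound 4 is 10%, between 0% and 25%.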

Compound 4, a percentage reported as inhibition, at one concentration (the size of the read-out at that concentration, not a potency): 4%
Beside the measured number, compound 4's estimate is 6 percentage points above it, and the stated range covers the measured number.
By their numbers in this assay, from the lowest: compounds 4, 2, 1 and 3 (each within the scatter of the next).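

In this assay, a much larger group on a saturated chain carbon bound to a sulfur, one with a six-membered aromatic ring and no hydrogen-bond donor, still leaves the number within the scatter (a number 4 percentage points lower from compound 1 to compound 4 (within the scatter)) and (a number 2 percentage points lower from compound 2 to compound 4 (within the scatter)). The carbamoyl group can therefore be exchanged here for either larger group without a readable change. No measurement at hand explains this flat result.

Going by these compounds, whether any group at this place can raise the number beyond the scatter remains open. A carboxylic acid in place of the methyl ester, or an amine, would test this.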